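A few compounds are considered here, and "the series" means these few. Any claim that something is new, unique, unknown or untested is made for them only; others in the source may bear on it.

Measured in a functional assay on A549 cells (Homo sapiens) for antiproliferative activity, read by sulforhodamine B assay, with a stated time of 48 h; on this read-out higher numbers stand for weaker inhibition and lower numbers for stronger inhibition:
- Compound 1 `COc1ccc2nc(-c3ccc(N/C=C\C(=O)c4cc(OC)c(OC)c(OC)c4)c(C)c3)sc2c1`: 11100 nM
- Compound 2 `COc1ccc2nc(-c3ccc(N/C=C\C(=O)c4ccc(OC)c([N+](=O)[O-])c4)c(C)c3)sc2c1`: 13600 nM
- Compound 3 `COc1ccc2nc(-c3ccc(N/C=C\C(=O)c4cc(OC)c(OC)c([N+](=O)[O-])c4)cc3)sc2c1`: 21600 nM

These three numbers sit close together. Compound 3, at 21600 nM, cannot be told apart from compound 1 or compound 2, since its gaps to both lie within the usual scatter of repeated measurements.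

Compound 4 `COc1ccc2nc(-c3ccc(N/C=C\C(=O)c4cc(OC)c(OC)c([N+](=O)[O-])c4)c(C)c3)sc2c1` has not yet been measured. It is compound 3 with one small edit, methyl in place of hydrogen on an aromatic carbon, ortho to a large group and meta to a 6-methoxy-1,3-benzothiazol-2-yl group.

Within the data shown here, no measured pair shows this edit alone, so the evidence is indirect. Compound 1 and compound 2 carry the same methyl but also differ from compound 3 elsewhere, and neither value stands beyond the scatter from compound 3.

The expected change in this assay is therefore none beyond the scatter, with an estimated 1.4-fold lower number from compound 3 to compound 4 (0.16 log units; within the scatter).

For compound 4 the estimated value is 15000 nM, with an expected range from 7000 nM to 32000 nM.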

Compound 4, half-maximal inhibitory concentration: 22100 nM
Beside the measured number, compound 4's estimate is 1.5-fold (0.17 log units) below it; measured number inside the range.
By their numbers in this assay, from the lowest: compounds 1, 2, 3 and 4 (each within the scatter of the next).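

In this assay the methyl ortho to a large group and meta to a 6-methoxy-1,3-benzothiazol-2-yl group can now be read on its own, and the step of a 1.0-fold higher number from compound 3 to compound 4 (0.01 log units; within the scatter) shows that this position accepts the extra carbon with no visible effect on the read-out. With the methyl in place, two other single edits also stay within the scatter: a methoxy group added to an aromatic carbon gives a 1.6-fold higher number from compound 2 to compound 4 (0.21 log units; within the scatter) and nitro in place of methoxy on an aromatic carbon gives a 2.0-fold higher number from compound 1 to compound 4 (0.30 log units; within the scatter) in this comparison. No independent measurement is available to explain these results.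

The compounds shown carry only hydrogen or methyl at this position, so it remains open whether an ethyl group, an amine or a carboxylic acid there would also leave the read-out unchanged. From the compounds shown here alone, whether the methyl matters in other kinds of cells also remains open.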